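From 3-chlorophenyl to 4-chlorophenyl in compound 2

A few compounds are considered here, and "the series" means these few. Any claim that something is new, unique, unknown or untested is made for them only; others in the source may bear on it.

Compound 1 `COc1ccccc1Oc1c(N)nc(-c2ccc(C)cc2)nc1OCCO`: 2380 nM
Compound 2 `COc1ccccc1Oc1c(N)nc(-c2cccc(Cl)c2)nc1OCCO`: 30200 nM

In a functional assay on A-375 cells (Homo sapiens) for cytotoxicity, read by CCK-8 assay, with a stated time of 24 h (on this read-out higher numbers stand for weaker inhibition and lower numbers for stronger inhibition), only these two compounds have been measured so far. Compound 2, at 30200 nM, has the higher number and is therefore the weaker inhibitor of the pair.

The unmeasured compound 3 `COc1ccccc1Oc1c(N)nc(-c2ccc(Cl)cc2)nc1OCCO` differs from compound 2 by one change: 4-chlorophenyl in place of 3-chlorophenyl on an aromatic carbon. It carries 4-chlorophenyl in place of 3-chlorophenyl, on the aromatic carbon between two ring nitrogen atoms.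

Within the data shown here, one measured step bears on this change, and it is large: a 13-fold higher number from compound 1 to compound 2 (1.10 log units; beyond the scatter). That step alters both the group and where it is substituted, so it cannot separate the two. Among the measured compounds shown here, no measured pair isolates the move of the chlorine alone. Even so, compound 3 resembles compound 1, at 2380 nM, in having its substituent at the 4-position of the phenyl group. A sizeable move back towards a lower number is therefore expected, though probably not the whole gap. The expected change is a 6.0-fold lower number from compound 2 to compound 3 (0.78 log units; beyond the scatter). In this assay, the estimate for compound 3 is 5000 nM, with an expected range from 1500 nM to 17000 nM.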

Compound 3, half-maximal inhibitory concentration: > 80000 nM
Compound 3: no number, only a limit; the forecaster's own chance of this, stated with the estimate: 3%; at least 16-fold (1.20 log units) between middle value and limit.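

In this assay compound 3 gives only a limit of the assay, not a number: the limit of > 80000 nM in this assay, at which 1 of the 3 values shown sits.

Even so, the limit is enough to read both new steps. With the chlorine kept and only its place on the phenyl group changed, 4-chlorophenyl in place of 3-chlorophenyl gives an at least 2.6-fold higher number from compound 2 to compound 3 (0.42 log units; beyond the scatter), which separates the place of the chlorine from the identity of the group in a way that the earlier pair could not. With the place kept and only the group changed, chloro in place of methyl gives an at least 33-fold higher number from compound 1 to compound 3 (1.52 log units; beyond the scatter), so the low number of compound 1 does not follow from the place of its substituent alone, and compound 3 stands against any such reading.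

From the compounds shown here alone, the true sizes of both steps stay open, since each rests on a limit, and so does the question of whether the chlorine's place matters as much with another group. A 3-methylphenyl analogue would test this for methyl, while plain phenyl, 4-fluorophenyl or 4-methoxyphenyl would show whether the low number of compound 1 is particular to the 4-methylphenyl group.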